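The source may report more compounds than this note shows. Statements on the series, on what has been measured and on what is new or still open speak of the compounds shown alone.

In an assay on microsomes from liver for inhibition of 3-hydroxy-3-methylglutaryl-coenzyme A reductase (Rattus norvegicus) (a higher number here means a weaker inhibitor, a lower number a stronger inhibitor), compound 3 `CC(C)c1nc(-c2ccc(F)cc2)c(-c2cc(Cl)cc(Cl)c2)n1/C=C/[C@@H](O)C[C@@H](O)CC(=O)O` gives 22 nM, and that number sits second highest among the three compounds measured. Compound 1 `O=C(O)C[C@H](O)C[C@H](O)CCn1c(C(F)(F)F)nc(-c2ccccc2)c1-c1ccc(F)cc1` gives 31 nM in this assay, which lies within the scatter of the value for compound 3. Compound 2 `CC(C)c1c(-c2ccc(F)cc2)nc(-c2ccc(F)cc2)n1/C=C/[C@@H](O)C[C@@H](O)CC(=O)O` gives 1 nM in this assay, the lowest of the three and the furthest from compound 3, by a gap beyond the scatter. Compound 4 `Cc1cc(F)ccc1-c1c(-c2ccc(F)cc2)nc(C(C)C)n1/C=C/[C@@H](O)C[C@@H](O)CC(=O)O` has not yet been measured; it differs from compound 3 by 4-fluoro-2-methylphenyl in place of 3,5-dichlorophenyl on an aromatic carbon. Because compound 2 carries a 4-fluorophenyl group at that ring atom and shows 1 nM, a step downward beyond the scatter, a 4.4-fold lower number from compound 3 to compound 4 (0.64 log units; beyond the scatter), is expected. Compound 4 is estimated at 5 nM, within 1.5 nM to 20 nM.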

Compound 4, half-maximal inhibitory concentration: 4 nM
Compound 4: the middle estimate sits 1.3-fold (0.10 log units) above what was measured; the measured number falls inside the stated range.
By their numbers in this assay, from the lowest: compound 2; then compound 4; then compounds 3 and 1 (each within the scatter of the next).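

In this assay, among the compounds shown here, 4-fluoro-2-methylphenyl in place of 3,5-dichlorophenyl gives a 5.5-fold lower number from compound 3 to compound 4 (0.74 log units; beyond the scatter), the first step here in which only one group changes, and it shows that the number responds to the aryl group on this aromatic carbon. The two groups have the same count of heavy atoms, so that count does not separate them. Nothing measured here accounts for the step. On these data alone, whether the methyl, the fluorine or the loss of the chlorines carries the step stays open. So does the effect of a methoxy group or an amine on that aryl ring.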